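Shortening the acyl chain on a benzophenone amide series

This account rests on a few compounds, and the source may have more. Where it says the series, first, only, none or still open, it means among the compounds named here.

Three compounds sharing the core of compound 1 `CN(C)CC(=O)NCC(=O)N(C)c1ccc(Cl)cc1C(=O)c1ccccc1Cl` have been tested in a functional assay on the whole organism with Mus musculus as the target, in the rotarod test; on this read-out higher numbers stand for an effect only at larger amounts of compound and lower numbers for an effect already at smaller amounts. Compound 1 gives 26 mg/kg. Compound 2 `CC(NC(=O)CN)C(=O)N(C)c1ccc(Cl)cc1C(=O)c1ccccc1Cl` gives 8.5 mg/kg, and compound 3 `CCCCC(=O)NCC(=O)N(C)c1ccc(Cl)cc1C(=O)c1ccccc1Cl` gives 90 mg/kg. Compound 3 thus stands at the highest number of the three: a 3.5-fold higher number from compound 1 to compound 3 (0.54 log units; beyond the scatter), and an 11-fold higher number from compound 2 to compound 3 (1.02 log units; beyond the scatter). The two steps that lead to compound 3 both replace a nitrogen-bearing end group with a plain hydrocarbon.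

Compound 4 `CC(C)C(=O)NCC(=O)N(C)c1ccc(Cl)cc1C(=O)c1ccccc1Cl` differs from compound 3 only at the acyl end: isopropyl in place of butyl on a carbonyl carbon. Both groups are plain hydrocarbons without donors or acceptors, so the measured steps speak to this change only indirectly. Step a 3.5-fold higher number from compound 1 to compound 3 (0.54 log units; beyond the scatter) is the closest, but it exchanges a dimethylamino group for propyl, not one alkyl for another. Among the measured compounds shown here, no measured pair varies the size or branching of an alkyl alone.

For the measured compounds named here, with no step bearing directly on it, the change from butyl to isopropyl is expected to give a step of a 1.3-fold lower number from compound 3 to compound 4 (0.11 log units; within the scatter), within the usual scatter. Compound 4 is therefore estimated at 70 mg/kg, with a range from 30 mg/kg to 180 mg/kg.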

Compound 4, dose for half-maximal effect: > 100 mg/kg
Compound 4: no number, only a limit (the forecaster's own chance of this, stated with the estimate: 10%); at least 1.4-fold (0.15 log units) between middle value and limit.
By their numbers in this assay, from the lowest: compound 2; then compound 1; then compound 3. At a limit, above all of these: compound 4.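

In this assay, compound 4 gives no number, only a limit of the assay: the limit of > 100 mg/kg in this assay, at which 1 of the 4 values shown sits. This is the first change shown that exchanges one alkyl group for another on the carbonyl carbon, yet an at least 1.1-fold higher number from compound 3 to compound 4 (0.04 log units; that floor lies within the scatter) gives only a floor, so this pair sets no order between the butyl and isopropyl end groups. The comparisons with the amine-bearing compounds are firmer, with an at least 11-fold higher number from compound 2 to compound 4 (1.07 log units; beyond the scatter) and an at least 3.8-fold higher number from compound 1 to compound 4 (0.58 log units; beyond the scatter); among the four compounds shown, both plain hydrocarbon end groups therefore sit on the high-number side of both amine-bearing end groups, with no compound going against this.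

As far as these compounds go, how far the true value of compound 4 lies past its limit remains open, and with it the size of the step from butyl to isopropyl, including whether branching or the shorter chain matters at this position. Also open, from the compounds shown here alone, is how this carbonyl carbon would respond to a straight ethyl group, a longer chain such as hexyl, or a carboxylic acid at the end of the chain.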